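Notes on compound 4: pentylsulfanyl replacing isobutoxy

This account rests on a few compounds, and the source may have more. Where it says the series, first, only, none or still open, it means among the compounds named here.

Measured so far in an assay on cells for antagonist activity at transient receptor potential cation channel subfamily V member 1 (Homo sapiens), read by FLIPR and calcium flux, with a stated time of 6 min; a higher number here means a weaker inhibitor, a lower number a stronger inhibitor:
compound 1, `CC(C(=O)NCc1ccc(C(C)(C)C)nc1N1CCCCCC1)c1ccc(NS(C)(=O)=O)c(F)c1`: 0.9 nM
compound 2, `CCC1CCN(c2nc(C(C)(C)C)ccc2CNC(=O)C(C)c2ccc(NS(C)(=O)=O)c(F)c2)CC1`: 0.1 nM
compound 3, `CC(C)COc1nc(C(C)(C)C)ccc1CNC(=O)C(C)c1ccc(NS(C)(=O)=O)c(F)c1`: 0.6 nM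

Compound 3 gives the second highest of the three numbers in this assay. The step of a 1.5-fold lower number from compound 1 to compound 3 (0.18 log units; within the scatter) lies within the scatter, so compound 1 and compound 3 cannot be ranked against each other; the step of a 6.0-fold higher number from compound 2 to compound 3 (0.78 log units; beyond the scatter) is the larger one and separates compound 3 from compound 2.

Compound 4, `CCCCCSc1nc(C(C)(C)C)ccc1CNC(=O)C(C)c1ccc(NS(C)(=O)=O)c(F)c1`, is not yet measured. It differs from compound 3 in one place: pentylsulfanyl in place of isobutoxy on an aromatic carbon. All three measured steps vary the group at this same aromatic carbon, so all bear on the change, though none of them exchanges an oxygen-linked chain for a sulfur-linked one. Two of them, a 9.0-fold lower number from compound 1 to compound 2 (0.95 log units; beyond the scatter) and a 6.0-fold higher number from compound 2 to compound 3 (0.78 log units; beyond the scatter), are modest; the third, a 1.5-fold lower number from compound 1 to compound 3 (0.18 log units; within the scatter), is within the scatter. Across the three groups tried at that carbon the numbers span a narrow band: compound 2 gives 0.1 nM and compound 1 gives 0.9 nM.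

Given that band, no step beyond the scatter is expected for compound 4 in this assay; the estimated step is a 1.2-fold higher number from compound 3 to compound 4 (0.07 log units; within the scatter). The value expected for compound 4 is 0.7 nM, with a range from 0.2 nM to 2.5 nM.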

Compound 4, inhibition constant: 3.1 nM
Compound 4: middle estimate off by 4.4-fold (0.65 log units), on the low side; the whole stated range lies below it.
By their numbers in this assay, from the lowest: compound 2; then compounds 3 and 1 (each within the scatter of the next); then compound 4.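

In this assay, pentylsulfanyl on this aromatic carbon next to the ring nitrogen gives the weakest inhibitor of the four compounds, with every step to it beyond the scatter (a 5.2-fold higher number from compound 3 to compound 4 (0.71 log units; beyond the scatter); a 3.4-fold higher number from compound 1 to compound 4 (0.54 log units; beyond the scatter); a 31-fold higher number from compound 2 to compound 4 (1.49 log units; beyond the scatter)). The position is therefore less forgiving than the narrow band of the earlier groups suggested, since compound 4, at 3.1 nM, lies outside the span from compound 2 at 0.1 nM to compound 1 at 0.9 nM. The change replaces the linking oxygen with sulfur and isobutoxy's chain with a pentyl chain together, and nothing measured here accounts for the loss or apportions it between those two differences.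

Still open, on these data alone, is whether the sulfur link or the pentyl chain carries the step, a question that pentyloxy and isobutylsulfanyl groups at this carbon would separate. Also open, as far as these compounds go, is whether the low number of compound 2, 0.1 nM, depends on its piperidine ring or would persist with an open-chain amine such as diethylamino.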